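A few compounds are considered here, and "the series" means these few. Any claim that something is new, unique, unknown or untested is made for them only; others in the source may bear on it.

The series is assessed in an ADME assay on HCT-116 cells (Homo sapiens) for cytotoxicity, read by CellTiter-Glo, with a stated time of 72 h; on this read-out lower numbers stand for stronger inhibition and higher numbers for weaker inhibition. Compound 1 `CC1CCN(C2CCN(S(=O)(=O)c3ccc(F)cc3F)CC2)CC1` gives > 5000 nM in this assay, which is a limit of the assay rather than a number. Compound 2 `CC1CCN(C2CCN(S(=O)(=O)c3nccn3C)CC2)CC1` gives > 10000 nM, again a limit. For the measured compounds named here, the only measured step, a step that the two limits leave unreadable from compound 1 to compound 2, is accordingly unreadable. Compound 3 `Cc1cc(C)c(S(=O)(=O)N2CCC(N3CCN(C)CC3)CC2)c(C)c1` gives > 5000 nM, once more a limit. It sits at the limit of > 5000 nM in this assay, at which 2 of the 3 values shown sit. The remaining value sits at the limit of > 10000 nM in this assay, at which 1 of the 3 values shown sits, so none of the three measured compounds yields a number in this assay.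

Compound 4 `Cc1cc(C)c(S(=O)(=O)N2CCC(N3CCCCC3)CC2)c(C)c1` has not yet been measured. It differs from compound 3 by piperidin-1-yl in place of 4-methylpiperazin-1-yl on a saturated ring carbon. Going by the values given here, no measured step bears on this change, and the single measured step is itself unreadable, so the numbers offer no readable precedent for movement in either direction. Compound 4 is expected to return a limit as well, with an estimate of 10000 nM and a range from 5000 nM to 40000 nM. The estimated step that the limit leaves unreadable from compound 3 to compound 4 is expected to stay within the scatter.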

Compound 4, half-maximal inhibitory concentration: > 5000 nM
Compound 4: only a limit was reported; the forecaster's own chance of this, stated with the estimate: 85%; the middle value lies beyond the limit too.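

In this assay compound 3 gives > 5000 nM, a limit and not a number. Compound 4 gives > 5000 nM, also a limit, so no step can be read between compound 3 and compound 4. The compounds shown leave open whether piperidin-1-yl and 4-methylpiperazin-1-yl differ at all in this read-out.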